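From Methyl Ester to Free Acid in Compound 4

The source may report more compounds than this note shows. Statements on the series, on what has been measured and on what is new or still open speak of the compounds shown alone.

Compound 3 `COC(=O)CCc1ccc(S(=O)(=O)NNc2ccc(Br)cc2)cc1` gives 121 nM in an assay for inhibition of Indoleamine 2,3-dioxygenase 1 (Homo sapiens), read by spectrophotometry, with stated times of 1 h and 4 h; on this read-out lower numbers stand for stronger inhibition and higher numbers for weaker inhibition. Among the three numbers so far it holds the lowest, though the gaps to its neighbours are small: compound 1 `CC(=O)Nc1ccc(S(=O)(=O)NNc2ccc(Br)cc2)cc1` gives 130 nM, and compound 2 `O=S(=O)(NNc1ccc(Br)cc1)c1ccccc1` gives 172 nM. The step of a 1.1-fold lower number from compound 1 to compound 3 (0.03 log units; within the scatter) and the step of a 1.4-fold lower number from compound 2 to compound 3 (0.15 log units; within the scatter) both stay within the scatter, as does the step of a 1.3-fold higher number from compound 1 to compound 2 (0.12 log units; within the scatter). Compound 4 `O=C(O)CCc1ccc(S(=O)(=O)NNc2ccc(Br)cc2)cc1` differs from compound 3 by hydrogen in place of methyl on an oxygen next to a carbonyl group. For the measured compounds named here, no measured step alters this exact spot; the steps that bear on it are the three that exchange the group on the aromatic carbon of the shared core, and each of them remained within the scatter. The expected step for compound 4 is therefore one that does not exceed the scatter, a 1.2-fold higher number from compound 3 to compound 4 (0.09 log units; within the scatter). The estimated value for compound 4 in this assay is 150 nM, with a range from 60 nM to 400 nM.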

Compound 4, half-maximal inhibitory concentration: 141 nM
Compound 4: middle estimate off by 1.1-fold (0.03 log units), on the high side; the measured number falls inside the stated range.
By their numbers in this assay, from the lowest: compounds 3, 1, 4 and 2 (each within the scatter of the next).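

For the compounds shown here, the change from methoxycarbonyl to carboxy, hydrogen in place of methyl on an oxygen next to a carbonyl group, gives the first reading at this spot, and in this assay the step stays within the scatter (a 1.2-fold higher number from compound 3 to compound 4 (0.07 log units; within the scatter)). The 2-carboxyethyl group also cannot be told apart from hydrogen (a 1.2-fold lower number from compound 2 to compound 4 (0.09 log units; within the scatter)) or acetamido (a 1.1-fold higher number from compound 1 to compound 4 (0.04 log units; within the scatter)), so none of the four groups on this aromatic carbon separates from another in this assay. Nothing available here bears on why these numbers stay so close.

The compounds shown leave open whether a primary amide or an amine in place of the carboxy group, or a longer chain carrying it, would move the number beyond the scatter. As far as these compounds go, all four also keep the bromo group, so its part in these numbers remains unknown.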